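From dimethylamino to dipropylamino on the shared core

The source may hold more compounds than are shown below. What is called first, only, known or untested is meant among the compounds shown, and "the series" means these compounds.

Compound 1 `CCCNc1ccc(NC(=O)c2cc(Cl)ccc2O)c(Cl)c1` gives 22500 nM
Compound 2 `CC(C)Nc1ccc(NC(=O)c2cc(Cl)ccc2O)c(Cl)c1` gives 11000 nM
Compound 3 `CN(C)c1ccc(NC(=O)c2cc(Cl)ccc2O)c(Cl)c1` gives 85100 nM

Compound 3 has the highest number of the three in an ADME assay on A549 cells (Homo sapiens) for cytotoxicity, read by resazurin assay, with a stated time of 48 h (a higher number here means that more compound is tolerated, a lower number that less compound is tolerated), and so is the best tolerated there. Among the compounds with values here, compound 4 `CCCN(CCC)c1ccc(NC(=O)c2cc(Cl)ccc2O)c(Cl)c1` has not yet been measured and carries dipropylamino in place of dimethylamino on an aromatic carbon as its only change. The closest evidence is a 3.8-fold higher number from compound 1 to compound 3 (0.58 log units; beyond the scatter) together with a 7.7-fold higher number from compound 2 to compound 3 (0.89 log units; beyond the scatter) and both steps are modest. Within the data shown here, no measured compound carries dipropylamino, so this evidence is indirect. A modest step downward is expected, with a 4.3-fold lower number from compound 3 to compound 4 (0.63 log units; beyond the scatter) as the estimated size. In this assay compound 4 is estimated at 20000 nM and expected to fall between 6000 nM and 60000 nM in repeat measurements.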

Compound 4, half-maximal cytotoxic concentration: 10700 nM
The estimate for compound 4 lay 1.9-fold (0.27 log units) above the measured number; low and high end bracket the measured number.
By their numbers in this assay, from the lowest: compounds 4 and 2 (each within the scatter of the next); then compound 1; then compound 3.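

In this assay, having no hydrogen on this nitrogen does not by itself keep the number high: with dipropylamino in place of dimethylamino there is an 8.0-fold lower number from compound 3 to compound 4 (0.90 log units; beyond the scatter), so the length of the chains matters here. A second propyl on the nitrogen of the propylamino group gives a 2.1-fold lower number from compound 1 to compound 4 (0.32 log units; beyond the scatter), while dipropylamino in place of isopropylamino gives a 1.0-fold lower number from compound 2 to compound 4 (0.01 log units; within the scatter), and these two groups cannot be told apart in this assay. Nothing measured here explains these shifts.

On these data alone, whether diethylamino would stay close to dimethylamino or to dipropylamino remains open, as does the effect of a ring amine such as morpholine at this position.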